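This account rests on a few compounds, and the source may have more. Where it says the series, first, only, none or still open, it means among the compounds named here.

Two analogues sharing one core were examined. Compound 1, `FC(F)(F)c1cccc(CNc2cc(C(F)(F)F)cc3[nH]ncc23)c1`, and compound 2, `FC(F)(F)c1cc(NCC2CNC2)c2cn[nH]c2c1`, were tested in an assay for inhibition of Indoleamine 2,3-dioxygenase 1 (Homo sapiens), with stated times of 10 min and 60 min, tested at 10 uM; a lower number here means a weaker effect, a higher number a stronger effect of the compound at the concentration tested. Compound 1 gave 25%, while compound 2 gave 10%, the lower of the two numbers, with compound 1 standing higher by a margin beyond the usual scatter. Compound 3, `Nc1cccc(CNc2cc(C(F)(F)F)cc3[nH]ncc23)c1`, differs from compound 2 by 3-aminophenyl in place of azetidin-3-yl on a saturated chain carbon bound to a nitrogen on an aromatic ring. Since compound 3 carries an aromatic ring at that position, as compound 1 does with its 25%, the expected step of a number 10 percentage points higher from compound 2 to compound 3 (within the scatter) is modest and upward, near the edge of the scatter. Compound 3 is estimated at 20%, within a range of 5% to 40%.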

Compound 3, a percentage reported as inhibition, at one concentration (the size of the read-out at that concentration, not a potency): 24%
Compound 3: middle estimate off by 4 percentage points, on the low side; measured number inside the range.
By their numbers in this assay, from the lowest: compound 2; then compounds 3 and 1 (each within the scatter of the next).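

In this assay, 3-aminophenyl in place of azetidin-3-yl on a saturated chain carbon bound to a nitrogen on an aromatic ring gives a number 14 percentage points higher from compound 2 to compound 3 (beyond the scatter), so this position responds to the change of group. Amino in place of trifluoromethyl on an aromatic carbon gives a number 1 percentage points lower from compound 1 to compound 3 (within the scatter), so this read-out does not separate these two groups. No evidence on the cause of either step is available.

From the compounds shown here alone, whether a carboxylic acid or a nitrile on that aromatic carbon would move the number remains open. So does the effect of a longer chain at the saturated chain carbon.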